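The compounds below may be only part of what the source reports. "The series", "measured", "known", "first", "only" and "open" are said of these compounds alone.

Two compounds share a core in which a sulfonamide joins a pyrimidinedione fragment to a phenyl that carries a triazole, and the triazole in turn bears an aryl on one of its ring nitrogens. Compound 1 `Cc1cccc(-n2cc(-c3cccc(NS(=O)(=O)c4c[nH]c(=O)[nH]c4=O)c3)nn2)c1` carries a 3-methylphenyl there, and in a functional assay on HepG2 cells (Homo sapiens) for antiproliferative activity, read by MTT assay, with a stated time of 24 h (a higher number here means a weaker inhibitor, a lower number a stronger inhibitor), compound 1 gives 7050 nM. Within the data shown here, compound 2 `O=c1[nH]cc(S(=O)(=O)Nc2cccc(-c3cn(-c4ccccc4Cl)nn3)c2)c(=O)[nH]1` carries a 2-chlorophenyl instead, and in this assay compound 2 gives 4030 nM, the lowest of the two numbers, its only neighbour being compound 1, since the change a 1.7-fold lower number from compound 1 to compound 2 (0.24 log units; within the scatter) stays within the scatter.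

Compound 3 `O=c1[nH]cc(S(=O)(=O)Nc2cccc(-c3cn(-c4ccc(Cl)cc4)nn3)c2)c(=O)[nH]1` moves the chlorine on that aryl: 4-chlorophenyl in place of 2-chlorophenyl on an aromatic nitrogen. Among the measured compounds shown here, no measured step exchanges one chlorophenyl for another; the only step in hand, the one from compound 1 to compound 2, swaps a different aryl for this one and was within the scatter. On that basis no shift beyond the scatter is expected in this assay, and the step of a 1.1-fold higher number from compound 2 to compound 3 (0.05 log units; within the scatter) is the estimate that follows. Compound 3 is accordingly expected to give about 4500 nM, with a range from 1500 nM to 13000 nM.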

Compound 3, half-maximal inhibitory concentration: 1960 nM
Estimate against measurement, compound 3: 2.3-fold (0.36 log units) above, within the range that was stated.
By their numbers in this assay, from the lowest: compound 3; then compounds 2 and 1 (each within the scatter of the next).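

Moving the chlorine from 2-chlorophenyl to 4-chlorophenyl leaves the heavy-atom count unchanged, yet in this assay the move gives a 2.1-fold lower number from compound 2 to compound 3 (0.31 log units; beyond the scatter) and is the first step at this aromatic nitrogen to pass the scatter, showing that where the chlorine sits on the aryl can be read here, as the earlier swap of 3-methylphenyl for 2-chlorophenyl could not show. Set against 3-methylphenyl, the 4-chlorophenyl group gives a 3.6-fold lower number from compound 1 to compound 3 (0.56 log units; beyond the scatter) and leaves compound 3 with the lowest number of the three, although both steps are only modest in size. Nothing measured here accounts for either step, so the result stands without an explanation.

On these data alone, whether the lower number belongs to the chlorine itself or to any group in that place stays open, since a 4-methylphenyl, 4-methoxyphenyl or 4-fluorophenyl group would separate the two, and a 3-chlorophenyl group would complete the set of chlorine placements. As far as these compounds go, it is also open whether an amine or a carboxylic acid on this aryl would keep or lose the lower number seen with 4-chlorophenyl.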